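Pyridazinone amides: tolyl-for-fluorophenyl swap, cytotoxicity estimate

This account rests on a few compounds, and the source may have more. Where it says the series, first, only, none or still open, it means among the compounds named here.

Measured so far:
compound 1, `Cc1cc(=O)n(-c2cccc(F)c2)nc1C(=O)Nc1ccc(Oc2ncnc3ccsc23)cc1`: 10200 nM
compound 2, `Cc1ccc(-n2nc(C(=O)Nc3ccc(Oc4ncnc5ccsc45)cc3)c(C)cc2=O)cc1`: 25000 nM
compound 3, `Cc1cc(=O)n(-c2cccc(F)c2)nc1C(=O)Nc1ccc(Oc2ncnc3ccsc23)c(F)c1`: 7810 nM

All three share one amide-linked core and were read in a functional assay on HepG2 cells (Homo sapiens) for cytotoxicity, read by MTT assay, with a stated time of 72 h; a higher number here means a weaker inhibitor, a lower number a stronger inhibitor. Compound 1 gives 10200 nM and compound 2 gives 25000 nM in this assay, the change between them being (4-methylphenyl in place of 3-fluorophenyl on an aromatic nitrogen), which gave a 2.5-fold higher number from compound 1 to compound 2 (0.39 log units; beyond the scatter). Compound 3 gives 7810 nM; its core differs from that of compound 1 by fluoro in place of hydrogen on an aromatic carbon, and this gave a 1.3-fold lower number from compound 1 to compound 3 (0.12 log units; within the scatter), so compound 1 and compound 3 cannot be ordered on these data.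

Compound 4, `Cc1ccc(-n2nc(C(=O)Nc3ccc(Oc4ncnc5ccsc45)c(F)c3)c(C)cc2=O)cc1`, is not yet measured. It differs from compound 3 by 4-methylphenyl in place of 3-fluorophenyl on an aromatic nitrogen, the same change that carried compound 1 to compound 2, on the same place and surroundings. Because a 2.5-fold higher number from compound 1 to compound 2 (0.39 log units; beyond the scatter) went beyond the scatter and because a 1.3-fold lower number from compound 1 to compound 3 (0.12 log units; within the scatter) stayed within it, the step from compound 3 to compound 4 is expected to be of similar size, roughly a 2.5-fold higher number from compound 3 to compound 4 (0.40 log units; beyond the scatter). Going by the values given here, with only one prior instance of this change, the estimate is held wide. Compound 4 is therefore estimated at 19500 nM in this assay, between 8000 nM and 48000 nM.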

Compound 4, half-maximal inhibitory concentration: 17300 nM
Estimate against measurement, compound 4: 1.1-fold (0.05 log units) above; low and high end bracket the measured number.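

In this assay, 4-methylphenyl in place of 3-fluorophenyl on an aromatic nitrogen gave a 2.2-fold higher number from compound 3 to compound 4 (0.35 log units; beyond the scatter), and this step does not differ from the earlier one on the core of compound 1: the same change on two cores in this assay, a 2.5-fold higher number (0.39 log units; beyond the scatter) from compound 1 to compound 2 and a 2.2-fold higher number (0.35 log units; beyond the scatter) from compound 3 to compound 4, 1.1-fold (0.04 log units) apart, within the scatter of two such steps
Fluoro in place of hydrogen on an aromatic carbon gave a 1.4-fold lower number from compound 2 to compound 4 (0.16 log units; within the scatter), so that pair cannot be ordered, and this small step also held when the group on the aromatic nitrogen changed: the same change on two cores in this assay, a 1.3-fold lower number (0.12 log units; within the scatter) from compound 1 to compound 3 and a 1.4-fold lower number (0.16 log units; within the scatter) from compound 2 to compound 4, 1.1-fold (0.04 log units) apart, within the scatter of two such steps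
The four compounds thus show the two changes acting independently of each other in this one cell assay, but they form a single square of two cores and two groups, which does not show that either change would carry to any other core in the series, and it gives no reason for the size of the steps.

Open, as far as these compounds go, is how a carboxylic acid, an amine or a longer alkyl chain would read in place of 3-fluorophenyl or 4-methylphenyl on the aromatic nitrogen. Also open, from the compounds shown here alone, is whether the steps would hold on a core changed elsewhere, such as at the amide hydrogen.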